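Swapping the Outer Ring of a Bombesin Receptor Agonist

This account rests on a few compounds, and the source may have more. Where it says the series, first, only, none or still open, it means among the compounds named here.

Three compounds have so far been tested in a functional assay on HEK293 cells for agonist activity at Bombesin receptor subtype-3 (Mus musculus), read by luminescence and calcium flux, with a stated time of 10 min; on this read-out higher numbers stand for an effect only at larger amounts of compound and lower numbers for an effect already at smaller amounts:
compound 1 `CCC(C)(C)Cc1c[nH]c(CCc2ccc(-c3ccncc3)cc2)n1` gives 15 nM
compound 2 `CCC(C)(C)Cc1c[nH]c(CCc2ccc(-c3cnccn3)cc2)n1` gives 11 nM
compound 3 `CCC(C)(C)Cc1c[nH]c(CCc2ccc(-c3cnsc3)cc2)n1` gives 6.9 nM

Compound 1 stands at the highest number of the three. The two changes made from it both replace the same outer ring. There is a 1.4-fold lower number from compound 1 to compound 2 (0.13 log units; within the scatter), a shift too small to count. There is also a 2.2-fold lower number from compound 1 to compound 3 (0.34 log units; beyond the scatter), a modest but real drop in the number. The shared core, with its long branched chain, was kept the same in every case.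

Compound 4 `CCC(C)(C)Cc1c[nH]c(CCc2ccc(-c3ccc(F)cn3)cc2)n1` continues this line. Compared with compound 1, the change is 5-fluoropyridin-2-yl in place of pyridin-4-yl on an aromatic carbon. Both measured steps bear on this one, since each swaps one small aromatic ring for another at the same place; they moved the number little, or only modestly downward. The same is therefore expected here: a step from compound 1 to compound 4 of about a 1.3-fold lower number from compound 1 to compound 4 (0.10 log units; within the scatter), most likely within the scatter or at most a modest drop. The estimate for compound 4 is 12 nM, expected to fall between 5 nM and 35 nM.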

Compound 4, half-maximal effective concentration: 16 nM
The estimate for compound 4 lay 1.3-fold (0.12 log units) below the measured number; measured number inside the range.
By their numbers in this assay, from the lowest: compounds 3, 2, 1 and 4 (each within the scatter of the next, the first and the last beyond it).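

In this assay, among these compounds, the outer ring can carry a fluorine and be joined through a different ring carbon with no real shift in the number (a 1.1-fold higher number from compound 1 to compound 4 (0.03 log units; within the scatter)), something the unsubstituted rings of the earlier compounds could not show. Compound 4 also stays level with the pyrazin-2-yl ring (a 1.5-fold higher number from compound 2 to compound 4 (0.16 log units; within the scatter)), so the pyridine and pyrazine versions form a close group at this position. The 1,2-thiazol-4-yl ring stands apart from compound 4 (a 2.3-fold higher number from compound 3 to compound 4 (0.37 log units; beyond the scatter)), though compound 2 blurs any clean split, since it lies within the scatter of both compound 3 and compound 4, and nothing measured here accounts for these differences.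

This step changes the ring's point of attachment and adds the fluorine in one move, so the two cannot be separated without a plain pyridin-2-yl ring for comparison. Also open, on these data alone, is how this position would respond to a larger or charged group on the outer ring, such as a methoxy group, an amine or a carboxylic acid.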